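Second Chloro on the Core of a Benzylpurine Series

This account rests on a few compounds, and the source may have more. Where it says the series, first, only, none or still open, it means among the compounds named here.

Three compounds of this series have a number in a functional assay on A498 cells (Homo sapiens) for cytotoxicity, read by sulforhodamine B assay, with a stated time of 48 h (on this read-out lower numbers stand for stronger inhibition of growth and higher numbers for weaker inhibition of growth), so far. Compound 1 `ClCc1ccc(Cn2cnc3c(Cl)ncnc32)cc1` gives 26900 nM, which is the second highest of the three numbers. Compound 3 `ClCc1ccccc1Cn1cnc2c(Cl)ncnc21` gives 32400 nM, within the scatter of compound 1, so no order between the two can be read. Compound 2 `ClCc1ccccc1Cn1cnc2c(Cl)nc(Cl)nc21` gives 4780 nM, well beyond the scatter from compound 1 and a lower number.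

Compound 4 `ClCc1ccc(Cn2cnc3c(Cl)nc(Cl)nc32)cc1` has not yet been measured in this assay. It differs from compound 1 in one place: chloro in place of hydrogen on an aromatic carbon. For the measured compounds named here, the only measured step that bears on this change is the one from compound 2 to compound 3, which is the same change run backwards, giving a 6.8-fold higher number from compound 2 to compound 3 (0.83 log units; beyond the scatter). That step stands in the pair where the chloromethyl group sits on the other position of the benzyl ring, but it is the closest guide available.

On that basis the same change in the forward direction is expected to bring a lower number for compound 4 by a step of about a 6.0-fold lower number from compound 1 to compound 4 (0.78 log units; beyond the scatter), and compound 4 is estimated at 4500 nM, with a range from 1500 nM to 13000 nM.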

Compound 4, concentration for total growth inhibition: 25100 nM
Estimate against measurement, compound 4: 5.6-fold (0.75 log units) below, and the stated range ends below it.
By their numbers in this assay, from the lowest: compound 2; then compounds 4, 1 and 3 (each within the scatter of the next).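

In this assay, chloro in place of hydrogen on the aromatic carbon between two ring nitrogen atoms gives a 1.1-fold lower number from compound 1 to compound 4 (0.03 log units; within the scatter), so no order can be read between these two compounds. The pair of compound 2 and compound 3 had shown the same change as a clear step, which means that the change has no single size in this series, and the two pairs differ in where the chloromethyl group sits on the benzyl ring: the same change on two cores in this assay, a 6.8-fold higher number (0.83 log units; beyond the scatter) from compound 2 to compound 3 and a 1.1-fold higher number (0.03 log units; within the scatter) from compound 4 to compound 1, 6.3-fold (0.80 log units) apart, beyond the scatter of two such steps The lower number of compound 2 against compound 3 therefore belongs to that pair alone and cannot be carried over to compound 1 and compound 4.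

For the compounds shown here, with only two pairs, it stays open which of them is the more typical, and whether the difference between them holds for other placements of the chloromethyl group on the benzyl ring. Going by these compounds, it is also open how a different group at this same carbon, such as an amine or a methoxy group, would behave on either side of the series, and whether a hydroxymethyl group in place of chloromethyl would keep the gap between the two pairs.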